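A methoxy swap on the benzyl ring of compound 2

This account rests on a few compounds, and the source may have more. Where it says the series, first, only, none or still open, it means among the compounds named here.

Measured so far in a functional assay on MDA-MB-231 cells (Homo sapiens) for inhibition, read by CCK-8 assay, with a stated time of 48 h; on this read-out lower numbers stand for stronger inhibition of growth and higher numbers for weaker inhibition of growth:
compound 1 `CN1CCN(c2ccc(Nc3ncc(Cl)c(Nc4ccccc4)n3)nc2)CC1` gives (37400 nM)
compound 2 `CN1CCN(c2ccc(Nc3ncc(Cl)c(NCc4ccc(F)cc4)n3)nc2)CC1` gives (> 100000 nM), which is a limit and not a number

Going by these compounds, compound 2 therefore has no exact position on the scale, and its true value remains unknown (the limit of > 100000 nM in this assay, at which 1 of the 2 values shown sits). Compound 3 `COc1cccc(CNc2nc(Nc3ccc(N4CCN(C)CC4)cn3)ncc2Cl)c1` differs from compound 2 in one place, on a saturated chain carbon bound to a nitrogen on an aromatic ring, where 3-methoxyphenyl stands in place of 4-fluorophenyl (3-methoxyphenyl in place of 4-fluorophenyl on a saturated chain carbon bound to a nitrogen on an aromatic ring).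

Going by the values given here, only one measured step is available as a guide (an at least 2.6-fold higher number from compound 1 to compound 2 (0.42 log units; beyond the scatter)). That step put 4-fluorobenzyl in place of phenyl on a nitrogen on an aromatic ring, and it moved the number upward, toward weaker inhibition of growth. It does not compare two substituted benzyl groups, so it gives only a loose guide to the new change. In this assay no large gain is expected, and the expected step is no more than modest (an at least 1.2-fold lower number from compound 2 to compound 3 (0.09 log units; that floor lies within the scatter)). For compound 3 the estimated value is (80000 nM), with an expected range from (30000 nM) to (150000 nM).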

Compound 3, concentration for 50% growth inhibition: 20300 nM
Beside the measured number, compound 3's estimate is 3.9-fold (0.60 log units) above it; the measured number lies below the stated range.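

Compound 2 stands at a limit of the assay and not at a number: the limit of > 100000 nM in this assay, at which 1 of the 3 values shown sits.

In this assay, changing 4-fluorophenyl to 3-methoxyphenyl on the saturated chain carbon gives an at least 4.9-fold lower number from compound 2 to compound 3 (0.69 log units; beyond the scatter), so the group carried on that carbon clearly matters; the earlier step, which replaced phenyl with 4-fluorobenzyl, could not show this because it did not compare two substituted benzyl groups. Nor does the saturated chain carbon by itself bring weak inhibition of growth: with 3-methoxybenzyl in place of phenyl, the result is a 1.8-fold lower number from compound 1 to compound 3 (0.27 log units; within the scatter), and that pair cannot be told apart in this read-out.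

The step to compound 3 removes a fluorine, adds a methoxy group and changes the group's place on the ring all at once, so the compounds shown cannot say which of these matters; 3-fluorobenzyl and 4-methoxybenzyl groups would help to separate them. Also open, going by these compounds, is how an amine or a carboxylic acid on the same benzyl ring would move the number.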